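A methoxy for a methyl in compound 4

The source may report more compounds than this note shows. Statements on the series, on what has been measured and on what is new or still open speak of the compounds shown alone.

In a functional assay on HepG2 cells (Homo sapiens) for antiproliferative activity, read by MTT assay, with a stated time of 72 h (a lower number here means a stronger inhibitor, a higher number a weaker inhibitor), compound 1 `COc1ncc(-c2ccc3c(c2)N(c2ccc(C)cc2)C(=O)CO3)cc1NS(=O)(=O)c1ccc(F)cc1` gives 28300 nM. That sits within the usual scatter of compound 3 `O=C1COc2ccc(-c3cnc4ccccc4c3)cc2N1c1ccc(F)cc1` at 37200 nM, while compound 2 `COc1cccc(N2C(=O)COc3ccc(-c4cnc5ccccc5c4)cc32)c1` shows a clearly lower number at 2080 nM.

Compound 4 `COc1ccc(N2C(=O)COc3ccc(-c4cnc(OC)c(NS(=O)(=O)c5ccc(F)cc5)c4)cc32)cc1` differs from compound 1 in one place: methoxy in place of methyl on an aromatic carbon. Put simply, methoxy takes the place of methyl on an aromatic carbon, turning 4-methylphenyl into 4-methoxyphenyl.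

Among the measured compounds shown here, only one measured step touches this part of the molecule: an 18-fold higher number from compound 2 to compound 3 (1.25 log units; beyond the scatter). It is large, so a swap on this ring can move the number a long way. Yet it exchanges different groups, and compounds 2 and 3 also differ from compound 1 elsewhere, which makes it a loose guide. Its methoxy-bearing member, compound 2 at 2080 nM, holds the lower number, so any shift should lean downward.

The estimated step is a 1.8-fold lower number from compound 1 to compound 4 (0.25 log units; within the scatter), so no clear change is expected in this assay. For compound 4 the expected value is 16000 nM, with an estimated range of 5000 nM to 45000 nM.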

Compound 4, half-maximal inhibitory concentration: 13100 nM
The estimate for compound 4 lay 1.2-fold (0.09 log units) above the measured number; the range from low to high includes it.
By their numbers in this assay, from the lowest: compound 2; then compound 4; then compounds 1 and 3 (each within the scatter of the next).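

Among the compounds shown here, compound 4 gives the first clean reading of this position: with the rest of compound 1 unchanged, turning 4-methylphenyl into 4-methoxyphenyl produces a 2.2-fold lower number from compound 1 to compound 4 (0.33 log units; beyond the scatter) in this assay. The earlier step between compounds 2 and 3 showed that this ring can matter a great deal, but it exchanged two different groups, whereas this step isolates methoxy against methyl on the sulfonamide-bearing compounds and shows a modest effect, only just past the usual scatter. No measurement shown accounts for the shift.

From the compounds shown here alone, it remains open whether a different group at this place, such as an amine or a chlorine atom, would move the number further. Going by these compounds, it is also open whether the same swap would act similarly on compounds 2 and 3, which differ from compound 1 elsewhere.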